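A few compounds are considered here, and "the series" means these few. Any claim that something is new, unique, unknown or untested is made for them only; others in the source may bear on it.

Measured so far:
- compound 1 `c1cnc2c(c1)CCC[C@@H]2N(CC1CC1)C[C@H]1Cc2c(cccc2N2CCNCC2)CN1`: 82.1%
- compound 2 `c1cnc2c(c1)CCC[C@@H]2N(CC1CCCCC1)C[C@H]1Cc2c(cccc2N2CCNCC2)CN1`: 81.6%

In an ADME assay on microsomes from liver (Homo sapiens) for metabolic stability, read by LC-MS, with a stated time of 10 min (a lower number here means that less of the compound is left, a higher number that more of the compound is left), compound 2 gives 81.6%. Compound 1 gives 82.1%, and the two are within the scatter of each other, the step being a number 0.5 percentage points lower from compound 1 to compound 2 (within the scatter). Compound 3 `CN(C[C@H]1Cc2c(cccc2N2CCNCC2)CN1)[C@H]1CCCc2cccnc21` differs from compound 2 by hydrogen in place of cyclohexyl on a saturated chain carbon bound to an amine nitrogen. Going by the values given here, the one measured step at that saturated chain carbon bound to an amine nitrogen, a number 0.5 percentage points lower from compound 1 to compound 2 (within the scatter), was within the scatter, but it did not remove the ring, so it bears only loosely on this change; no step beyond the scatter is expected. Compound 3 is estimated at 79%, between 60% and 94%, an expected step of a number 2.6 percentage points lower from compound 2 to compound 3 (within the scatter).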

Compound 3, percent of the compound remaining: 99.7%
Compound 3: middle estimate off by 20.7 percentage points, on the low side; measured number outside the range, above it.
By their numbers in this assay, from the lowest: compounds 2 and 1 (each within the scatter of the next); then compound 3.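

In this assay, replacing the ring-bearing groups at this place, on a saturated chain carbon bound to an amine nitrogen, gives a number 18.1 percentage points higher from compound 2 to compound 3 (beyond the scatter) and a number 17.6 percentage points higher from compound 1 to compound 3 (beyond the scatter) at the same place. Cyclopropyl and cyclohexyl stand within the scatter of each other, so the earlier pair did not show that hydrogen in place of either ring would separate compound 3 from both. Nothing shown here accounts for this difference. The compounds shown leave open whether an ethyl group or a longer chain at this place would stay close to compound 3 or to compound 1 and compound 2.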